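The source may hold more compounds than are shown below. What is called first, only, known or untested is meant among the compounds shown, and "the series" means these compounds.

For the measured compounds named here, in a functional assay on HepG2 cells (Homo sapiens) for antiproliferative activity, read by XTT assay, with a stated time of 72 h (on this read-out higher numbers stand for weaker inhibition and lower numbers for stronger inhibition), the values so far are these.

- Compound 1 `COc1ncnc2c1c(-c1ccccc1)cn2[C@@H]1O[C@H](CO)[C@@H](O)[C@H]1O` gives > 20000 nM as a limit of the assay
- Compound 2 `CSc1ncnc2c1c(-c1ccoc1)cn2[C@@H]1O[C@H](CO)[C@@H](O)[C@H]1O` gives > 15000 nM as a limit of the assay
- Compound 3 `CNc1ncnc2c1c(-c1ccco1)cn2[C@@H]1O[C@H](CO)[C@@H](O)[C@H]1O` gives 850 nM as a measured number

Going by the values given here, compound 3 therefore holds the only true number in the set, and the two other entries are limits rather than numbers. Among the compounds with values here, that leaves little to compare it with directly, and no step between two measured compounds is available as a guide.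

The next compound, compound 4 `CNc1ncnc2c1c(-c1ccoc1)cn2[C@@H]1O[C@H](CO)[C@@H](O)[C@H]1O`, differs from compound 3 in one place. It has furan-3-yl in place of furan-2-yl on an aromatic carbon, so the two have the same atoms, joined differently.

Compound 2 also bears furan-3-yl, and its value of > 15000 nM is a limit. It differs from compound 4 in another group as well, so it offers only a weak hint toward weaker inhibition. Compound 3, at 850 nM, is the closer reference, and it suggests that compound 4 should stay in a similar range.

The step of a 2.4-fold higher number from compound 3 to compound 4 (0.37 log units; beyond the scatter) is expected to be modest and toward weaker inhibition in this assay, though it could prove larger. For compound 4 the estimated value is 2000 nM, with an expected range from 400 nM to 12000 nM as the measurement is awaited.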

Compound 4, half-maximal inhibitory concentration: > 20000 nM
Compound 4 was reported as a limit; the forecaster's own chance of this, stated with the estimate: 15%; middle value at least 10-fold (1.00 log units) away from the limit.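

In this assay, for the compounds shown here, swapping furan-2-yl for furan-3-yl on the same aromatic carbon, with the same atoms and every other part of the molecule unchanged, gives an at least 23-fold higher number from compound 3 to compound 4 (1.37 log units; beyond the scatter); this is the first readable step in the set, and it shows that the point at which the furan is joined to the core matters greatly here. Compound 4 gives > 20000 nM, which is a limit of the assay and not a number. With this result, compound 3 remains the only compound with a true number, while compound 4 joins the compounds reported only as limits: the limit of > 20000 nM in this assay, at which 2 of the 4 values shown sit.

On these data alone, the step from compound 2 to compound 4, which places methylamino where methylsulfanyl stood, cannot be read, as both of its values are limits, so the effect of that group on a furan-3-yl compound stays unknown. Also open, as far as these compounds go, is whether the value of compound 3 would hold with thiophen-2-yl in place of furan-2-yl, or with ethylamino or dimethylamino in place of methylamino.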